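Chloro to Amino on the Shared Core of Compound 1

A few compounds are considered here, and "the series" means these few. Any claim that something is new, unique, unknown or untested is made for them only; others in the source may bear on it.

Of the compounds shown here, two have so far been measured in a functional assay on PC-3 cells (Homo sapiens) for cytotoxicity, read by sulforhodamine B assay, with a stated time of 48 h; on this read-out higher numbers stand for weaker inhibition of growth and lower numbers for stronger inhibition of growth. Compound 1, `ClCc1ccccc1Cn1cnc2c(Cl)nc(Cl)nc21`, gives 440 nM in this assay. Compound 2, `ClCc1cccc(Cn2cnc3ncnc(Cl)c32)c1`, gives 2130 nM in this assay. Of the two numbers, that of compound 1 is the lower, and the gap to compound 2 lies beyond the scatter of repeated runs. The two compounds differ in more than one place, so no single step can be read from them.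

Compound 3, `Nc1nc(Cl)c2ncn(Cc3ccccc3CCl)c2n1`, has not yet been measured in this assay. It differs from compound 1 by one change: amino in place of chloro on an aromatic carbon. Going by the values given here, no measured pair in this set shows what such an exchange does on this core, so any expectation rests on compound 1 alone.

A step in this assay that is beyond the scatter is expected, toward weaker inhibition of growth, but of modest size; the estimated step is a 2.0-fold higher number from compound 1 to compound 3 (0.31 log units; beyond the scatter). For compound 3, the estimate in this assay is 900 nM, with a range from 250 nM to 3000 nM.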

Compound 3, concentration for 50% growth inhibition: 15100 nM
For compound 3 the middle estimate is 17-fold (1.22 log units) below the measured one; the measured number lies above the stated range.
By their numbers in this assay, from the lowest: compound 1; then compound 2; then compound 3.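

In this assay, going by these compounds alone, the exchange of chloro for amino on the aromatic carbon between two ring nitrogen atoms gives a 34-fold higher number from compound 1 to compound 3 (1.54 log units; beyond the scatter) and is the first single change that can be read in this set. The two earlier compounds differ in more than one place, so they could not show that this position on the shared core is sensitive to what it carries. Here the chloro group goes with clearly stronger inhibition of growth than the amino group, and the step is large and well beyond the scatter, although only one heavy atom is exchanged. Nothing at hand accounts for the size of this step, so the result stands as an observation on this one pair.

The compounds shown leave open whether the loss follows amino specifically or would also appear with another group at this carbon, such as methylamino, methoxy or a thiol. They also leave open whether amino in place of the remaining chloro group, which compound 3 keeps, would produce a step of similar size.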